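The compounds below may be only part of what the source reports. "The series", "measured", "known", "first", "only" and "open" are said of these compounds alone.

Working notes on the series.

Compound 1 `O=C(c1ccc2c(c1)ncn2-c1ccccc1)N1CCCCC1` gives 22 nM in an assay on isolated protein for inhibition of 15-hydroxyprostaglandin dehydrogenase [NAD(+)] (Homo sapiens), read by fluorescence, with a stated time of 15 min; a higher number here means a weaker inhibitor, a lower number a stronger inhibitor. Compound 2 `COc1ccc(-n2cnc3cc(C(=O)N4CCCCC4)ccc32)cc1` gives 19 nM in this assay, the lower of the two numbers, though the step of a 1.2-fold lower number from compound 1 to compound 2 (0.06 log units; within the scatter) leaves the two compounds within the scatter of each other, so no order between them can be claimed.

The next step goes from compound 2 to compound 3 `CC(C)(C)n1cnc2cc(C(=O)N3CCCCC3)ccc21`, not yet measured in this assay. The change is tert-butyl in place of 4-methoxyphenyl on an aromatic nitrogen. For the measured compounds named here, no measured step bears directly on this change: the only step in hand, a 1.2-fold lower number from compound 1 to compound 2 (0.06 log units; within the scatter), adds a methoxy on the aryl group and does not remove the aryl group itself. The data therefore give no direct guide, and the change is larger than anything yet measured in the series. A weaker inhibitor is expected, since a whole aromatic ring leaves; the size of the shift is uncertain. For compound 3 the estimated step is a 3.7-fold higher number from compound 2 to compound 3 (0.57 log units; beyond the scatter). Compound 3 is expected to give about 70 nM in this assay, with a range from 15 nM to 400 nM.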

Compound 3, half-maximal inhibitory concentration: 34 nM
Compound 3: middle estimate off by 2.1-fold (0.31 log units), on the high side; low and high end bracket the measured number.
By their numbers in this assay, from the lowest: compounds 2, 1 and 3 (each within the scatter of the next).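

For the compounds shown here, on the aromatic nitrogen of the five-membered ring, the earlier compounds only varied a substituent on the aryl group, whereas compound 3 shows that the aromatic ring itself can be replaced by a group with no ring while the number in this assay stays within the scatter. Tert-butyl in place of 4-methoxyphenyl gives a 1.8-fold higher number from compound 2 to compound 3 (0.25 log units; within the scatter) and tert-butyl in place of phenyl gives a 1.5-fold higher number from compound 1 to compound 3 (0.19 log units; within the scatter) so neither step separates compound 3 from the aryl compounds, even though the 4-methoxyphenyl group has 8 heavy atoms and tert-butyl has 4. No measurement in hand accounts for this result.

The three compounds leave open how far this tolerance extends on that nitrogen, for example whether methyl, a longer chain, or a chain ending in an amine or a carboxylic acid would still stay within the scatter. On these data alone, the rest of the molecule is the same in all three compounds, so the effect of any change elsewhere on the core or at the amide remains open as well.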